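The source may report more compounds than this note shows. Statements on the series, on what has been measured and on what is new or still open speak of the compounds shown alone.

Measured so far:
compound 1 `CCCCCCCCc1ccc(CCC(CO)(CO)NC(=O)CCC)c2ccccc12`; in a functional assay on HT-29 cells (Homo sapiens) for antiproliferative activity, read by sulforhodamine B assay, with a stated time of 72 h (on this read-out higher numbers stand for weaker inhibition and lower numbers for stronger inhibition), compound 1 gives 26400 nM
compound 2 `CCCCCCCCc1ccc(CCC(CO)(CO)NC(=O)CCCCCCC)c2ccccc12`; in this assay compound 2 gives 22000 nM
compound 3 `CCCCCCCOc1ccc(CCC(CO)(CO)NC(C)=O)c2ccccc12`; in this assay compound 3 gives 17600 nM

Compound 1 and compound 2 share a core and differ by butyl in place of hydrogen on a saturated chain carbon, three bonds along the chain from a carbonyl carbon. The step reads a 1.2-fold lower number from compound 1 to compound 2 (0.08 log units; within the scatter). Compound 3 has another core; the difference between the core of compound 3 and the core of compound 1 is not broken down here. The three measured values all lie within the scatter of one another.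

Compound 4 `CCCCCCCOc1ccc(CCC(CO)(CO)NC(=O)CCCCC)c2ccccc12` is not yet measured. It differs from compound 3 by butyl in place of hydrogen on a saturated chain carbon bound to a carbonyl carbon. Around the place the two changes are not identical: the butyl in compound 2 enters on a saturated chain carbon, three bonds along the chain from a carbonyl carbon, while the butyl in compound 4 enters on a saturated chain carbon bound to a carbonyl carbon. It is the same kind of change, not the same.

Compound 4 is expected to show a step of a 1.2-fold lower number from compound 3 to compound 4 (0.07 log units; within the scatter) in this assay. This expectation rests on the step of a 1.2-fold lower number from compound 1 to compound 2 (0.08 log units; within the scatter). Compound 4 is thus estimated at 15000 nM, with a range from 7000 nM to 32000 nM.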

Compound 4, half-maximal inhibitory concentration: 21900 nM
Compound 4: middle estimate off by 1.5-fold (0.16 log units), on the low side, and the stated range covers the measured number.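

In this assay, butyl in place of hydrogen on the core of compound 3 gives a 1.2-fold higher number from compound 3 to compound 4 (0.09 log units; within the scatter). Set beside the earlier step, the two cores do not separate on this kind of change: the same change on two cores in this assay, a 1.2-fold lower number (0.08 log units; within the scatter) from compound 1 to compound 2 and a 1.2-fold higher number (0.09 log units; within the scatter) from compound 3 to compound 4, 1.5-fold (0.17 log units) apart, within the scatter of two such steps. This shows only that, in both pairs, the butyl leaves the read-out within the scatter; it does not show that a real effect carries from one core to the other, since the butyl enters at a different place in each pair and steps this small could hide a real effect of either sign.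

As far as these compounds go, all four compounds keep the hydroxymethyl groups and an amide bearing a plain saturated chain, so it stays open whether any change to that chain can move the number beyond the scatter on either core. An amine or a carboxylic acid in place of the butyl, or a longer chain there, would put that question to the test.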